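A few compounds are considered here, and "the series" means these few. Any claim that something is new, unique, unknown or untested is made for them only; others in the source may bear on it.

Measured compounds:
- compound 1, `COc1cc(/C=C/C(=O)c2cccc(-n3cc(-c4ccccc4)[nH]c3=O)c2)ccc1O`, 1910 nM in a functional assay on SF-539 cells (Homo sapiens) for inhibition; a lower number here means a stronger inhibitor of growth, a higher number a weaker inhibitor of growth
- compound 2, `O=C(/C=C/c1cccc(O)c1)c1cccc(-n2cc(-c3ccc(Cl)cc3)[nH]c2=O)c1`, 1680 nM in this assay
- compound 3, `COc1cc(/C=C/C(=O)c2cccc(-n3cc(-c4ccccc4)[nH]c3=O)c2)cc(OC)c1OC`, 1680 nM in this assay

Compound 3 stands level with compound 2 at the digits given, and the two share the lowest number of the three; compound 1 lies nearest above it by a margin that sits inside the usual scatter, so nothing here separates the three compounds. Compound 1 and compound 3 differ only in the methoxy groups on the cinnamoyl side, and their values in this assay agree within the scatter.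

Compound 4, `COc1cc(/C=C/C(=O)c2cccc(-n3cc(-c4cc(OC)c(OC)c(OC)c4)[nH]c3=O)c2)cc(OC)c1OC`, carries the change (3,4,5-trimethoxyphenyl in place of phenyl on an aromatic carbon). Going by the values given here, no pair of measured compounds shows a step of this kind, so the expectation rests on the flat picture among compounds 1, 2 and 3. The writer expects a small downward step, a 1.4-fold lower number from compound 3 to compound 4 (0.15 log units; within the scatter), with the possibility that it stays within the scatter. Compound 4 is estimated at 1200 nM, with a range from 400 nM to 3500 nM.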

Compound 4, concentration for 50% growth inhibition: 3120 nM
Estimate against measurement, compound 4: 2.6-fold (0.41 log units) below, within the range that was stated.
By their numbers in this assay, from the lowest: compounds 2, 3, 1 and 4 (each within the scatter of the next).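

Placing 3,4,5-trimethoxyphenyl instead of phenyl on this aromatic carbon of the five-membered aromatic ring gives a 1.9-fold higher number from compound 3 to compound 4 (0.27 log units; within the scatter) in this assay. This is the only step shown at this position, and it shows that a group of 12 heavy atoms with 3 hydrogen-bond acceptors can stand in place of the 6 heavy atoms of phenyl without the read-out moving beyond the scatter. Nothing measured here offers an explanation for this result.

The compounds shown leave open whether a single methoxy group, an amine or a carboxylic acid on this phenyl would leave the read-out equally flat. Compound 2 carries a chlorine on this ring but also differs on the cinnamoyl side, so the effect of that chlorine alone remains unresolved.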